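The compounds below may be only part of what the source reports. "The series", "measured", "known", "first", "only" and "open" are said of these compounds alone.

The measured compounds and their values in a physicochemical assay for solubility, with a stated time of 18 h, at pH 7.4 (on this read-out higher numbers stand for higher solubility and lower numbers for lower solubility), are:
compound 1, `COc1ccc(Oc2ccc3c(NCCCNCc4cccc(OC)c4O)ccnc3c2)cc1`, with 14500 nM;
compound 2, `COc1cccc(CNCCCNc2ccnc3cc(Oc4cccc(N(C)C)c4)ccc23)c1O`, with 14500 nM;
compound 3, `COc1cccc(CNCCCNc2ccnc3cc(Cc4ccc(F)cc4Cl)ccc23)c1O`, with 4200 nM.

Compound 3 stands lowest of the three: a 3.5-fold lower number from compound 1 to compound 3 (0.54 log units; beyond the scatter) and a 3.5-fold lower number from compound 2 to compound 3 (0.54 log units; beyond the scatter), while no change at the digits printed from compound 1 to compound 2 (within the scatter). Compound 4, `COc1cccc(CNCCCNc2ccnc3cc(-c4ccc(C(C)(C)C)cc4)ccc23)c1O`, has not yet been measured in this assay. It differs from compound 3 in one place: 4-(tert-butyl)phenyl in place of 2-chloro-4-fluorobenzyl on an aromatic carbon. No measured step involves the entering 4-(tert-butyl)phenyl group, so nothing shown bears directly on it. The two steps that concern the leaving 2-chloro-4-fluorobenzyl group were both modest, and the remaining step stayed within the scatter, so the three values together span a narrow range. Compound 4 is therefore expected to land close to compound 3, with no step beyond the scatter, a 1.4-fold lower number from compound 3 to compound 4 (0.15 log units; within the scatter). The estimate for compound 4 in this assay is 3000 nM, within a range from 1000 nM to 9000 nM.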

Compound 4, solubility: 32000 nM
For compound 4 the middle estimate is 11-fold (1.03 log units) below the measured one; the whole stated range lies below it.
By their numbers in this assay, from the lowest: compound 3; then compounds 1 and 2 (each within the scatter of the next); then compound 4.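

Until now, the groups at this aromatic carbon had given either no change or a drop in this assay, whereas 4-(tert-butyl)phenyl gives the highest number of the four compounds, with its steps from the other three all printed as beyond the scatter. The largest is the replacement of 2-chloro-4-fluorobenzyl, a 7.6-fold higher number from compound 3 to compound 4 (0.88 log units; beyond the scatter), and the number also clears both aryl ethers, with a 2.2-fold higher number from compound 2 to compound 4 (0.34 log units; beyond the scatter) and a 2.2-fold higher number from compound 1 to compound 4 (0.34 log units; beyond the scatter), so a group made of carbon alone can stand here without the number falling to that of compound 3. No measurement shown accounts for these steps, and the counts do not separate the two groups by hydrogen-bond donors, acceptors or net charge.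

The step from compound 3 to compound 4 changes the benzyl link, the chlorine and fluorine, and the tert-butyl group all at once, so the compounds shown cannot assign it to any one of these. From the compounds shown here alone, it remains open where an unsubstituted phenyl or a 4-(tert-butyl)benzyl group would fall at this position, and whether a carboxylic acid or an amine on the phenyl ring would keep the number of compound 4.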